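Carboxy in Place of Trifluoromethyl: Solubility Expectation

The source may report more compounds than this note shows. Statements on the series, on what has been measured and on what is new or still open speak of the compounds shown alone.

Measured compounds:
compound 1, `Fc1ccc(-c2nc3cnc(Nc4ccc(C(F)(F)F)cn4)cc3[nH]2)cc1F`: >= 50000 nM in a physicochemical assay for solubility, using the shake flask method, in simulated intestinal fluid, measured as kinetic solubility, with a stated time of 20 h, at pH 6.5; a higher number here means a more soluble compound, a lower number a less soluble compound
compound 2, `FC(F)(F)c1ccc(Nc2cc3[nH]c([C@H]4CC[C@H](C(F)(F)F)CC4)nc3cn2)nc1`: 104000 nM in this assay

In this assay compound 1 reaches only a limit of the assay, >= 50000 nM, not an exact number. The step that the limit leaves unreadable from compound 1 to compound 2 stays unreadable because of the limit of >= 50000 nM in this assay, at which 1 of the 2 values shown sits. Compound 3, `O=C(O)c1ccc(Nc2cc3[nH]c(-c4ccc(F)c(F)c4)nc3cn2)nc1`, differs from compound 1 by carboxy in place of trifluoromethyl on an aromatic carbon. Among the measured compounds shown here, no measured step covers this change, so the expectation rests on the limit of compound 1 alone, with no direction beyond the scatter assignable. Compound 3 is therefore estimated at 120000 nM, with a range from 50000 nM to 400000 nM. The expected step that the limit leaves unreadable from compound 1 to compound 3 cannot be checked against a number for compound 1.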

Compound 3, solubility: 9000 nM
Beside the measured number, compound 3's estimate is 13-fold (1.12 log units) above it; the measured number lies below the stated range.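

Carboxy in place of trifluoromethyl on an aromatic carbon, two atoms from the ring nitrogen, gives an at least 5.5-fold lower number from compound 1 to compound 3 (0.74 log units; beyond the scatter) in this assay, the only step among these compounds whose direction can be read. For compound 1 the value >= 50000 nM is a limit of the assay, not a number. This step therefore has only a smallest size, and the step to compound 2 cannot be read: the limit of >= 50000 nM in this assay, at which 1 of the 3 values shown sits.

Going by these compounds, how an amine or a methyl ester at this place would read in this assay stays open. So does whether the same change gives a similar step with 4-(trifluoromethyl)cyclohexyl in place of 3,4-difluorophenyl.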